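Trimming a chain on the way to a smaller analogue

The compounds below may be only part of what the source reports. "The series", "measured", "known", "first", "only" and "open" are said of these compounds alone.

Compound 1 `COc1ccc(N(C)c2nc(C)nc3ccccc23)cc1C(=O)NCC[Se]C#N` and compound 2 `Cc1nc(N(C)c2ccc([Se]C#N)c(F)c2)c2ccccc2n1` were both tested in a functional assay on HCT-116 cells (Homo sapiens) for inhibition, read by MTT assay, with a stated time of 48 h; a lower number here means a stronger inhibitor, a higher number a weaker inhibitor. Compound 1 gives 313 nM, the higher of the two numbers, while compound 2 gives 20 nM, and the gap between them lies beyond the scatter. Compound 3 `COc1ccc(N(C)c2nc(C)nc3ccccc23)cc1[Se]C#N` differs from compound 1 in one place: a group of 3 heavy atoms (1 carbon, 1 nitrogen, 1 selenium; no ring) in place of a group of 8 heavy atoms (4 carbon, 2 nitrogen, 1 oxygen, 1 selenium; no ring), on an aromatic carbon. Among the measured compounds shown here, no measured pair shows this exact step, so the expectation rests on compound 2, which also carries its group of 3 heavy atoms on an aromatic carbon and gives 20 nM. A drop beyond the scatter is expected, a 6.3-fold lower number from compound 1 to compound 3 (0.80 log units; beyond the scatter). Compound 3 is estimated at 50 nM, with a range from 15 nM to 170 nM.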

Compound 3, half-maximal inhibitory concentration: 34 nM
The estimate for compound 3 lay 1.5-fold (0.17 log units) above the measured number, and the stated range covers the measured number.
By their numbers in this assay, from the lowest: compounds 2 and 3 (each within the scatter of the next); then compound 1.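

Among the compounds shown here, on an aromatic carbon ortho to a methoxy group, this is the first direct reading of a change at this position: in this assay, swapping the group of 8 heavy atoms for the group of 3 heavy atoms gives a 9.2-fold lower number from compound 1 to compound 3 (0.96 log units; beyond the scatter), so the longer group with its amide hydrogen is not needed for a low number here. Nothing measured here explains this step. The compounds shown leave open how the number responds to other groups at this position, such as an amine, a carboxylic acid or a chain of intermediate length.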